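The source may report more compounds than this note shows. Statements on the series, on what has been measured and on what is new or still open speak of the compounds shown alone.

Series notes. Compound 1 `O=c1c(C(=S)Nc2ccccc2)coc2cc(Cl)ccc12` is the reference point. In a functional assay on OVCAR-3 cells (Homo sapiens) for inhibition, read by sulforhodamine B assay, with a stated time of 48 h (a lower number here means a stronger inhibitor, a higher number a weaker inhibitor), compound 1 reaches only the limit of the assay, > 100000 nM, and so gives no number. Within the data shown here, a second member, compound 2 `O=c1c(C2N=C(c3ccccc3)SS2)coc2ccc(Cl)cc12`, is measured in this assay at 66500 nM; no single-place step links compound 2 to compound 1, so the two values merely stand side by side. What the measured set shows is thin: the limit of > 100000 nM in this assay, at which 1 of the 2 values shown sits.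

Compound 3 `O=c1c(C(=S)Nc2ccccc2)coc2cc(Cl)c(Cl)cc12` is not yet measured in this assay. It differs from compound 1 by chloro in place of hydrogen on an aromatic carbon, ortho to a chloro group, meta to a fused ring and para to a fused ring. Among the measured compounds shown here, no measured pair shows the effect of such a change, so the expectation rests on compound 1, which in this assay gave > 100000 nM as a limit. The expected step is small, an at least 1.1-fold lower number from compound 1 to compound 3 (0.04 log units; that floor lies within the scatter), towards stronger inhibition if anything, but not clearly beyond the scatter. Compound 3 is estimated at 90000 nM, with a range from 30000 nM to 250000 nM, and a real chance that this assay again reports only a limit.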

Compound 3, half-maximal inhibitory concentration: > 100000 nM
Compound 3: no number, only a limit; the forecaster's own chance of this, stated with the estimate: 50%; middle value at least 1.1-fold (0.04 log units) from the limit.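

Compound 1 and compound 3 both give only a limit in this assay, so no step can be read between them. Whether chloro in place of hydrogen on an aromatic carbon of the core of compound 1 shifts inhibition at all stays open, with the values shown gathered at one point: the limit of > 100000 nM in this assay, at which 2 of the 3 values shown sit.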